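This account rests on a few compounds, and the source may have more. Where it says the series, first, only, none or still open, it means among the compounds named here.

Of the compounds shown here, three have been measured so far in an assay on Sf9 cells for inhibition of protein deacetylase HDAC6 (Homo sapiens), read by fluorescence; a higher number here means a weaker inhibitor, a lower number a stronger inhibitor. Compound 1 `O=C(O)c1cccc(-c2nnn(Cc3ccc(C(=O)NO)cc3)n2)c1` gives 12 nM, which places it second highest of the three numbers. Compound 3 `O=C(NO)c1cc(F)c(Cn2nnc(-c3ccco3)n2)c(F)c1` gives 3 nM, a lower number than compound 1 by a margin beyond the usual scatter. Compound 2 `CC(=O)Nc1ccc(C(=O)NO)cc1`, the smallest of the three, gives 270 nM, a far higher number than compound 1, again well beyond the scatter. All three share a hydroxamic acid on a benzene ring; compounds 1 and 3 carry additional rings beyond that, and both sit well below compound 2 despite differing widely from each other in those outer parts.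

Compound 4 `O=C(NO)c1ccc(Cn2nnc(-c3ccccc3)n2)cc1` has not yet been measured. It differs from compound 1 in a single place: hydrogen in place of carboxy on an aromatic carbon. For the measured compounds named here, no measured pair differs in only one place, so there is no directly comparable step to lean on. The change removes a small group at the outer edge of the molecule and leaves the rest of compound 1 intact. The step of a 1.5-fold lower number from compound 1 to compound 4 (0.18 log units; within the scatter) is expected to be small, if anything toward a lower number, and most likely within the scatter. For compound 4 in this assay the estimate is 8 nM, with a range from 3 nM to 25 nM.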

Compound 4, half-maximal inhibitory concentration: 3 nM
For compound 4 the middle estimate is 2.7-fold (0.43 log units) above the measured one; the measured number falls inside the stated range.
By their numbers in this assay, from the lowest: compounds 3 and 4 (each within the scatter of the next); then compound 1; then compound 2.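

In this assay, for the compounds shown here, the step of a 4.0-fold lower number from compound 1 to compound 4 (0.60 log units; beyond the scatter) is the first comparison here between two compounds that differ in only one place, and it isolates the effect of swapping carboxy for hydrogen. The position in question is on an aromatic carbon of a six-membered aromatic ring of carbon only, meta to a large group, and the result shows that carboxy is not needed there for a low number: the compound with plain hydrogen gives the lower number, by a modest margin beyond the scatter. Nothing available explains why removing this group lowers the number, so the step stands as an observation only.

As far as these compounds go, with only carboxy and hydrogen compared at this position, it remains open whether a methyl ester, an amine or a single fluorine atom there would behave like carboxy, like hydrogen or like neither. From the compounds shown here alone, it is also open whether moving carboxy to another carbon of the same ring would give a step of similar size, since this single pair speaks for one position alone.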